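From dimethylcarbamoyl to dimethylsulfamoyl on the ring amine nitrogen

This account rests on a few compounds, and the source may have more. Where it says the series, first, only, none or still open, it means among the compounds named here.

In a functional assay on HCT-116 cells (Homo sapiens) for cytotoxicity, read by sulforhodamine B assay, with a stated time of 48 h (on this read-out higher numbers stand for weaker inhibition and lower numbers for stronger inhibition), compound 1 `CC(=O)n1nc(NC(=O)c2ccccc2)c2c1CN(C(=O)c1ccccc1)C2` gives 580 nM, compound 2 `CC(=O)n1nc(NC(=O)c2ccccc2)c2c1CN(C(=O)c1cccc(F)c1)C2` gives 21900 nM and compound 3 `CC(=O)n1nc(NC(=O)c2ccccc2)c2c1CN(C(=O)N(C)C)C2` gives 70300 nM, the highest number of the three and the weakest inhibition. Compound 4 `CC(=O)n1nc(NC(=O)c2ccccc2)c2c1CN(S(=O)(=O)N(C)C)C2` carries dimethylsulfamoyl in place of dimethylcarbamoyl on an amine nitrogen in a ring. Going by the values given here, no measured step makes this exchange, so the evidence is indirect. Replacing the group on the same carbonyl carbon gives a 120-fold higher number from compound 1 to compound 3 (2.08 log units; beyond the scatter), which is large, and a 3.2-fold higher number from compound 2 to compound 3 (0.51 log units; beyond the scatter), which is modest. A fluoro in place of hydrogen on an aromatic carbon gives a 38-fold higher number from compound 1 to compound 2 (1.58 log units; beyond the scatter), which is also large. All three steps lie beyond the scatter, so the exchange is not assumed to be silent. Compound 3 already stands at the top of the three numbers, which leaves a lower number as the more likely direction. In this assay the expected step is a 2.3-fold lower number from compound 3 to compound 4 (0.37 log units; beyond the scatter), modest in size and uncertain in direction. For compound 4 the estimated value is 30000 nM, with an expected range from 6000 nM to 120000 nM.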

Compound 4, half-maximal inhibitory concentration: 35300 nM
For compound 4 the middle estimate is 1.2-fold (0.07 log units) below the measured one; low and high end bracket the measured number.
By their numbers in this assay, from the lowest: compound 1; then compounds 2, 4 and 3 (each within the scatter of the next, the first and the last beyond it).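

In this assay, dimethylsulfamoyl in place of dimethylcarbamoyl on the ring amine nitrogen gives a 2.0-fold lower number from compound 3 to compound 4 (0.30 log units; within the scatter), so this exchange does not separate the two groups, although the earlier compounds had shown large steps at this nitrogen. The new group also cannot be told apart from (3-fluorophenyl)carbonyl, with a 1.6-fold higher number from compound 2 to compound 4 (0.21 log units; within the scatter), while benzoyl remains clearly apart, with a 61-fold higher number from compound 1 to compound 4 (1.78 log units; beyond the scatter); among these four compounds, only compound 1 stands out from the rest. Nothing measured here explains these numbers.

The compounds shown leave open whether a benzenesulfonyl group on this nitrogen would give a number close to that of compound 1 or to that of compound 4. They also leave open how a smaller methanesulfonyl group or a simple acetyl group would compare there.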